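Removing the aromatic chloro from compound 2

The compounds below may be only part of what the source reports. "The series", "measured", "known", "first", "only" and "open" are said of these compounds alone.

Within the data shown here, compound 2 `O=C1Nc2ccccc2[C@]12N[C@H](c1ccccc1)[C@H](c1ccccc1)[C@@]21CCc2c([nH]c3ccc(Cl)cc23)C1=O` gives, in a functional assay on MCF7 cells (Homo sapiens) for antiproliferative activity, read by MTT assay, with a stated time of 48 h (on this read-out lower numbers stand for stronger inhibition and higher numbers for weaker inhibition), 18000 nM, a number that stands beside the only other measured member, compound 1 `Cc1ccc2[nH]c3c(c2c1)CC[C@]1(C3=O)[C@@H](c2ccccc2)[C@@H](c2ccccc2)N[C@@]12C(=O)Nc1ccccc12`, which in this assay gives 19000 nM; the two differ only within the scatter. Among the measured compounds shown here, the sole step between measured compounds, a 1.1-fold lower number from compound 1 to compound 2 (0.02 log units; within the scatter), exchanged methyl for chloro on an aromatic carbon and changed nothing beyond the scatter. Compound 3 `O=C1Nc2ccccc2[C@]12N[C@H](c1ccccc1)[C@H](c1ccccc1)[C@@]21CCc2c([nH]c3ccccc23)C1=O` differs from compound 2 by hydrogen in place of chloro on an aromatic carbon; the place is an aromatic carbon of a six-membered aromatic ring of carbon only, part of a fused or bridged system of six rings, meta to a fused ring and para to a fused ring. For the measured compounds named here, no measured step removes a substituent at that position altogether; the one step that touches it, a 1.1-fold lower number from compound 1 to compound 2 (0.02 log units; within the scatter), stayed within the scatter. The expected result for compound 3 is therefore a step of a 1.2-fold higher number from compound 2 to compound 3 (0.07 log units; within the scatter), not beyond the scatter. Compound 3 is estimated at 21000 nM, with a range from 8000 nM to 55000 nM.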

Compound 3, half-maximal inhibitory concentration: 15000 nM
Compound 3: the middle estimate sits 1.4-fold (0.15 log units) above what was measured, and the stated range covers the measured number.
By their numbers in this assay, from the lowest: compounds 3, 2 and 1 (each within the scatter of the next).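

In this assay, taking the chloro off altogether gives a 1.2-fold lower number from compound 2 to compound 3 (0.08 log units; within the scatter) and exchanging the methyl for hydrogen gives a 1.3-fold lower number from compound 1 to compound 3 (0.10 log units; within the scatter), so both steps to the bare aromatic carbon stay within the scatter. The earlier pair compared only one substituent with another, whereas compound 3 adds the unsubstituted reference, and neither chloro nor methyl at this place is shown to change the number relative to hydrogen. No supporting data bear on why these three compounds read alike.

On these data alone, whether an amine, a carboxylic acid or a longer alkyl chain on this aromatic carbon would move the number beyond the scatter remains open. Also open, as far as these compounds go, is whether a change elsewhere on the shared core would do so.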